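Swapping an Aryl Group Without a Cytotoxicity Baseline

The compounds below may be only part of what the source reports. "The series", "measured", "known", "first", "only" and "open" are said of these compounds alone.

Compound 1 (`COc1ccc([C@@H]2OC[C@H]3O[C@@H](c4ccccc4)[C@H](OC)[C@@H](OC)[C@@H]3O2)cc1`) offers no number to start from: in a functional assay on HEL cells (Homo sapiens) for cytotoxicity (on this read-out higher numbers stand for lower toxicity in this test and lower numbers for higher toxicity in this test), compound 1 stands at "not determined" (no result reported) and so sets no baseline. Among the compounds with values here, the only reading so far is a limit. Compound 2 (`CO[C@@H]1[C@@H](OC)[C@H](c2ccccc2)O[C@@H]2CO[C@@H](c3ccc(-c4ccccc4)cc3)O[C@@H]12`) gives > 50 ug/mL as a limit of the test, not a number. Compound 3 (`CO[C@@H]1[C@@H](OC)[C@H](c2ccccc2)O[C@@H]2CO[C@@H](c3ccc4ccccc4c3)O[C@@H]12`) carries naphthalen-2-yl in place of 4-methoxyphenyl on a saturated ring carbon. Within the data shown here, with no measured step to guide this change, the expected step in this assay is none beyond the usual scatter. Compound 3 is expected to read 50 ug/mL with an estimated range from 20 ug/mL to 100 ug/mL in this test.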

Compound 3, half-maximal cytotoxic concentration: > 50 ug/mL
Compound 3: no number, only a limit (the forecaster's own chance of this, stated with the estimate: 70%); the middle value lies on the limit itself.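

Compound 1 has no reported result and compound 3 gives only a limit, so no step can be read between them. Going by these compounds, whether naphthalen-2-yl in place of 4-methoxyphenyl changes the result in this assay remains open.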